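The compounds below may be only part of what the source reports. "The series", "measured", "known", "first", "only" and "open" are said of these compounds alone.

Of the compounds shown here, two sharing one core have been measured so far. In an ADME assay on the whole organism with Oryza sativa as the target, tested at 1 uM (on this read-out higher numbers stand for a weaker effect at the one concentration tested and lower numbers for a stronger effect), compound 1 `CCc1cccc(NC(=O)N[C@@H](C)c2ccccc2)c1` gives 94%. Compound 2 `C[C@@H](NC(=O)Nc1cccc(F)c1)c1ccccc1` gives 95% in this assay, a number that sits at the top of the two shown yet differs from compound 1 only within the usual scatter. Compound 3 `C[C@H](NC(=O)Nc1cccc(F)c1)c1ccccc1` awaits measurement; it is built like compound 2, with one difference: the two compounds have the same atoms and bonds and differ only in configuration as drawn: 1 of 1 stereo elements differ; a stereocentre at a saturated chain carbon is drawn R in compound 2 and S in compound 3. Within the data shown here, no step between two measured compounds is on record, so the size of any shift in this assay is an open question, and no shift beyond the scatter is expected. Compound 3 is therefore estimated at 93%, between 80% and 100%, an expected step of a number 2 percentage points lower from compound 2 to compound 3 (within the scatter).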

Compound 3, a percentage reported as activity, at one concentration (the size of the read-out at that concentration, not a potency): 94%
Compound 3: middle estimate off by 1 percentage points, on the low side; the measured number falls inside the stated range.
By their numbers in this assay, from the lowest: compounds 1, 3 and 2 (each within the scatter of the next).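

In this assay, reversing the stereocentre at the saturated chain carbon gives a number 1 percentage points lower from compound 2 to compound 3 (within the scatter), so this read-out does not separate the two drawn configurations. Fluoro in place of ethyl on an aromatic carbon, now seen as a single change, gives no change at the digits printed from compound 1 to compound 3 (within the scatter). The first of these steps has only one structural change behind it: the fact that compounds 2 and 3 differ only in the configuration as drawn

No step shown so far lies beyond the scatter, so what could move this read-out remains unknown. An amine or a carboxylic acid in place of fluoro on that aromatic carbon might still do so.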